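Swapping the triazole substituent in a cytotoxicity series

A few compounds are considered here, and "the series" means these few. Any claim that something is new, unique, unknown or untested is made for them only; others in the source may bear on it.

Of the compounds shown here, three built on one shared core have been tested in an ADME assay on HeLa cells (Homo sapiens) for cytotoxicity, read by MTT assay; on this read-out higher numbers stand for weaker inhibition and lower numbers for stronger inhibition. Compound 1 `COc1ccc(C[C@H]2COC(=O)[C@@H]2Cc2ccc(OCC(=O)N3CCCCC3)c(OC)c2)cc1OC` gives 293000 nM in this assay. Compound 2 `COc1ccc(C[C@H]2COC(=O)[C@@H]2Cc2ccc(OC(=O)CCC(=O)N3CCCC3)c(OC)c2)cc1OC` gives 201000 nM, and the step of a 1.5-fold lower number from compound 1 to compound 2 (0.16 log units; within the scatter) sits on an oxygen on an aromatic ring, away from the triazole. For compound 3 `COc1ccc(-n2cc(COc3ccc(C[C@H]4C(=O)OC[C@@H]4Cc4ccc(OC)c(OC)c4)cc3OC)nn2)cc1` this assay reports only a limit, >= 600000 nM, which is the limit of >= 600000 nM in this assay, at which 1 of the 3 values shown sits. Compound 4 `COc1ccc(C[C@H]2COC(=O)[C@@H]2Cc2ccc(OCc3cn(Cc4ccccc4Cl)nn3)c(OC)c2)cc1OC` carries the change (2-chlorobenzyl in place of 4-methoxyphenyl on an aromatic nitrogen). Among the measured compounds shown here, no measured step touches that position, and the single step that exists lies within the scatter, so nothing here points to a change. The step of a number no higher from compound 3 to compound 4 (the limit leaves the size open) is therefore expected to stay within the scatter. Compound 4 is estimated at 600000 nM, between 200000 nM and 1500000 nM, most likely again only a limit.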

Compound 4, half-maximal inhibitory concentration: 84500 nM
Compound 4: the middle estimate sits 7.1-fold (0.85 log units) above what was measured; the whole stated range lies above it.
By their numbers in this assay, from the lowest: compound 4; then compounds 2 and 1 (each within the scatter of the next). At a limit, above all of these: compound 3.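

This position does matter in this assay: 2-chlorobenzyl in place of 4-methoxyphenyl on the aromatic nitrogen brings the number down (an at least 7.1-fold lower number from compound 3 to compound 4 (0.85 log units; beyond the scatter)). Among the compounds shown here, the earlier compounds offered no measured step here, and their only step lay within the scatter. The value of compound 3 is a limit, not a number, so the true size of this step remains unknown: the limit of >= 600000 nM in this assay, at which 1 of the 4 values shown sits.

The compounds shown cannot separate the effect of the chlorine from that of the benzyl linkage. A plain benzyl group or an aminoethyl chain on this nitrogen would test this further.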